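A few compounds are considered here, and "the series" means these few. Any claim that something is new, unique, unknown or untested is made for them only; others in the source may bear on it.

Measured compounds:

compound 1 `C#CC[C@]1(O)[C@@H](CO)O[C@@H](n2ccc(=O)[nH]c2=O)[C@@H]1O` gives > 350000 nM in a functional assay on L1210 cells (Mus musculus), read by MTT assay; a lower number here means a stronger inhibitor, a higher number a weaker inhibitor; this value is a limit of the assay.
compound 2 `C#CC[C@@]1(O)[C@@H](CO)O[C@@H](n2ccc(=O)[nH]c2=O)[C@@H]1O` gives > 350000 nM in this assay; this value is also a limit of the assay.
compound 3 `CC[C@@]1(O)[C@@H](CO)O[C@@H](n2ccc(N)nc2=O)[C@@H]1O` gives 269000 nM in this assay.

Compound 2 stands at the limit of this assay, and its value is not a number. Among the compounds with values here, the only step measured, a step that the two limits leave unreadable from compound 1 to compound 2, cannot be read because of the limit of > 350000 nM in this assay, at which 2 of the 3 values shown sit, although the two compounds differ only in configuration, as the fact that compounds 1 and 2 differ only in the configuration as drawn states. Within the data shown here, compound 3 is the sole compound with a measured number, and it carries a different base and a different chain, so it shows only that a weak inhibitor of this kind can be read at all.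

Compound 4 `C=C[C@@]1(O)[C@@H](CO)O[C@@H](n2ccc(=O)[nH]c2=O)[C@@H]1O` differs from compound 2 by vinyl in place of propargyl on a saturated ring carbon. Among the measured compounds shown here, no measured step covers this change, so the only guide is the position of compound 2 at the limit. Compound 4 is therefore expected to stay at or near that limit, with a step of a number no higher from compound 2 to compound 4 (the limit leaves the size open) that means no change beyond the scatter. The estimate for compound 4 is 350000 nM, with a range from 100000 nM to 1000000 nM.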

Compound 4, half-maximal inhibitory concentration: 148000 nM
Beside the measured number, compound 4's estimate is 2.4-fold (0.37 log units) above it; the range from low to high includes it.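

In this assay, vinyl in place of propargyl on this saturated ring carbon gives an at least 2.3-fold lower number from compound 2 to compound 4 (0.37 log units; beyond the scatter), a change beyond the usual scatter. This shows that the number responds to the group at this position, and that swapping one short carbon chain for another here is enough to give a readable value with this base. The value of compound 2, > 350000 nM, is a limit of the assay and not a number.

As far as these compounds go, the step between compound 1 and compound 2 cannot be read, so what the configuration at this carbon does remains open: the limit of > 350000 nM in this assay, at which 2 of the 4 values shown sit. Also open, from the compounds shown here alone, is whether a longer chain or an amine on this carbon would move the number further, and whether vinyl would have the same effect with the base of compound 3.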